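The source may report more compounds than this note shows. Statements on the series, on what has been measured and on what is new or still open speak of the compounds shown alone.

Measured compounds:

compound 1 `COc1cc(-c2cc(/C=C/C(=O)c3ccc(N)cc3)[nH]n2)cc(OC)c1OC` gives 6720 nM
compound 2 `COc1ccc(C(=O)/C=C/c2cc(-c3cc(OC)c(OC)c(OC)c3)n[nH]2)cc1OC` gives 5530 nM
compound 3 `COc1ccc(-c2cc(/C=C/C(=O)c3ccc(N)cc3)[nH]n2)cc1OC` gives 7980 nM

All three numbers come from a functional assay on LOX IMVI cells (Homo sapiens) for inhibition, read by sulforhodamine B assay, with a stated time of 48 h; on this read-out higher numbers stand for lower toxicity in this test and lower numbers for higher toxicity in this test. The three values lie close together, and no one of them is set apart from the others. Going from compound 3 to compound 1, the change is methoxy in place of hydrogen on an aromatic carbon, and the step is a 1.2-fold lower number from compound 3 to compound 1 (0.07 log units; within the scatter). Going from compound 1 to compound 2 the step is a 1.2-fold lower number from compound 1 to compound 2 (0.08 log units; within the scatter). The difference between the core of compound 2 and the core of compound 3 is not broken down here.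

Compound 4 `COc1cc(C(=O)/C=C/c2cc(-c3cc(OC)c(OC)c(OC)c3)n[nH]2)cc(OC)c1OC` has not yet been measured in this assay. Among the measured compounds shown here, it differs from compound 2 by methoxy in place of hydrogen on an aromatic carbon, which is the same change as the one from compound 3 to compound 1, made at a place described in the same words. Because that earlier change gave a 1.2-fold lower number from compound 3 to compound 1 (0.07 log units; within the scatter), the expected step from compound 2 to compound 4 is a 1.2-fold lower number from compound 2 to compound 4 (0.06 log units; within the scatter), a small one. On that basis compound 4 is estimated at 4800 nM, most likely between 2400 nM and 9600 nM.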

Compound 4, concentration lethal to 50% of the cells: 5570 nM
Compound 4: the middle estimate sits 1.2-fold (0.06 log units) below what was measured; low and high end bracket the measured number.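

Adding the methoxy group to the aromatic carbon of compound 2 gives a 1.0-fold higher number from compound 2 to compound 4 (0.00 log units; within the scatter) in this assay, a step that stays within the usual scatter of repeated measurements. Set beside the earlier case, the two steps agree: the same change on two cores in this assay, a 1.2-fold lower number (0.07 log units; within the scatter) from compound 3 to compound 1 and a 1.0-fold higher number (0.00 log units; within the scatter) from compound 2 to compound 4, 1.2-fold (0.08 log units) apart, within the scatter of two such steps. This shows that the change left the number within the scatter on both of these cores, but neither step stands clear of the scatter, so it does not show that the methoxy group has any effect of its own that could carry from one core to another, and two cores make no rule for the whole series.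

The compounds shown leave open what other groups would do on that aromatic carbon, such as a fluorine atom, a hydroxyl group or an ethoxy group in place of the methoxy. From the compounds shown here alone, only this one cell test appears here, and whether the same holds in any other test remains open.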